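Swapping hydroxy for 2-bromoethyl on a chain

The source may hold more compounds than are shown below. What is called first, only, known or untested is meant among the compounds shown, and "the series" means these compounds.

Measured so far in a functional assay on HL-60 cells (Homo sapiens) for cytotoxicity, read by MTT assay, with a stated time of 24 h; on this read-out lower numbers stand for stronger inhibition and higher numbers for weaker inhibition:
- compound 1 `CC(C)(C)OC(=O)N1CCCN(CCCCCOc2c(Br)cc(Br)cc2Oc2ccc(Br)cc2Br)CC1`: 44.8 ug/mL
- compound 2 `OCCCOc1c(Br)cc(Br)cc1Oc1ccc(Br)cc1Br`: 29.9 ug/mL
- compound 3 `CC(C)(C)OC(=O)N1CCN(CCCCCOc2c(Br)cc(Br)cc2Oc2ccc(Br)cc2Br)CC1`: 32.1 ug/mL

Repeated measurements of this kind never agree exactly, so small gaps between numbers carry no meaning. Compound 2, at 29.9 ug/mL, cannot be separated from the other two, because compound 3 at 32.1 ug/mL and compound 1 at 44.8 ug/mL both lie within the usual scatter of it.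

The next compound to be tested is compound 4 `BrCCCCCOc1c(Br)cc(Br)cc1Oc1ccc(Br)cc1Br`. It is made from compound 2 by one structural change: 2-bromoethyl in place of hydroxy on a saturated chain carbon, three bonds along the chain from an oxygen on an aromatic ring. The change sits on a saturated chain carbon, three bonds along the chain from an oxygen on an aromatic ring. Cut one bond further out, the same difference reads 3-hydroxypropyl to 5-bromopentyl.

Among the measured compounds shown here, no two measured compounds differ in just one place, so the data hold no direct guide to the size of this step. For the measured compounds named here, the three values so far do sit close together in this assay, and that suggests no large move in either direction. The expected change is a 1.2-fold higher number from compound 2 to compound 4 (0.07 log units; within the scatter), which would be no shift beyond the scatter. For compound 4 the estimated value is 35 ug/mL, with an expected range from 15 ug/mL to 80 ug/mL.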

Compound 4, half-maximal inhibitory concentration: 25.7 ug/mL
Estimate against measurement, compound 4: 1.4-fold (0.13 log units) above; the measured number falls inside the stated range.
By their numbers in this assay, from the lowest: compounds 4, 2, 3 and 1 (each within the scatter of the next).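

In this assay, among the compounds shown here, putting 2-bromoethyl in place of hydroxy gives a 1.2-fold lower number from compound 2 to compound 4 (0.07 log units; within the scatter) and so offers the first direct comparison between two compounds that differ in one place. On this saturated chain carbon, three bonds along the chain from an oxygen on an aromatic ring, the change removes the hydrogen-bond donor and acceptor of hydroxy and adds two carbons and a bromine, yet the two compounds cannot be told apart on this read-out. No measurement is available that would explain why this step stays so small.

The step changes the chain end and the chain length together, as the same difference also reads 3-hydroxypropyl to 5-bromopentyl, so the compounds shown cannot say what each part contributes, and a 5-hydroxypentyl or 3-bromopropyl chain on the same core would be needed to pull the two apart. On these data alone, it also remains open whether this position stays as unresponsive with an amine or a carboxylic acid at the chain end, or with a much longer chain.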